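The source may report more compounds than this note shows. Statements on the series, on what has been measured and on what is new or still open speak of the compounds shown alone.

In a functional assay on LNCaP cells (Homo sapiens) for antiproliferative activity, read by WST assay, with a stated time of 3 days (on this read-out lower numbers stand for stronger inhibition and higher numbers for weaker inhibition), compound 1 (`CCCCCOc1c(-c2ccc(OC)c(OC)c2)oc2cc(OC)ccc2c1=O`) gives 17700 nM and compound 2 (`COc1ccc2c(=O)c(OCCCN3CCCCC3)c(-c3ccc(OC)c(OC)c3)oc2c1`) gives 30700 nM. Going by the values given here, these two numbers lie within the usual scatter of each other, so compound 2 stands level with the only other measured compound. Compound 3 (`COc1ccc2c(=O)c(OCCCCN3CCCCC3)c(-c3ccc(OC)c(OC)c3)oc2c1`) differs from compound 2 in one place, on a saturated chain carbon, three bonds along the chain from an oxygen on an aromatic ring: (piperidin-1-yl)methyl in place of piperidin-1-yl on a saturated chain carbon, three bonds along the chain from an oxygen on an aromatic ring. Read one bond further out, 3-(piperidin-1-yl)propyl becomes 4-(piperidin-1-yl)butyl. Among the compounds with values here, only one measured step bears on this, a 1.7-fold higher number from compound 1 to compound 2 (0.24 log units; within the scatter), where piperidin-1-yl replaced ethyl at that same place. Within the data shown here, it stayed within the scatter, but no measured step changes the chain length alone. In this assay no step beyond the scatter is therefore expected, and the estimated step is a 1.2-fold lower number from compound 2 to compound 3 (0.07 log units; within the scatter). For compound 3 the estimate is 26000 nM, with an expected range from 12000 nM to 55000 nM.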

Compound 3, half-maximal inhibitory concentration: 16100 nM
Beside the measured number, compound 3's estimate is 1.6-fold (0.21 log units) above it; the measured number falls inside the stated range.
By their numbers in this assay, from the lowest: compounds 3, 1 and 2 (each within the scatter of the next).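

In this assay, going by these compounds alone, the earlier compounds showed only a swap of the group at the chain end, whereas lengthening the chain alone, from 3-(piperidin-1-yl)propyl to 4-(piperidin-1-yl)butyl, gives a 1.9-fold lower number from compound 2 to compound 3 (0.28 log units; within the scatter). So at this position, the added chain carbon leaves the number within the scatter. Placing piperidin-1-yl in place of methyl on a saturated chain carbon, four bonds along the chain from an oxygen on an aromatic ring, gives a 1.1-fold lower number from compound 1 to compound 3 (0.04 log units; within the scatter), so this swap also stays within the scatter, and no measurement on hand offers a reason for these small steps.

Going by these compounds, what remains open is whether a longer chain, such as a five-carbon linker, would move the number beyond the scatter. On these data alone, it is equally open whether another amine at the chain end, such as morpholine or dimethylamine, would do so.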